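A few compounds are considered here, and "the series" means these few. Any claim that something is new, unique, unknown or untested is made for them only; others in the source may bear on it.

Compound 1 `COc1ccc(/C=C/[C@@](C)(/C=C/c2ccc(O)c(C=O)c2)CCC=C(C)C)cc1` gives > 49000 nM
Compound 2 `COc1ccc(/C=C/[C@@](C)(/C=C/c2ccc(O)c(/C=C/C#N)c2)CCC=C(C)C)cc1` gives > 49000 nM
Compound 3 `CCOC(=O)/C(C)=C/c1cc(/C=C/[C@](C)(/C=C/c2ccc(OC)cc2)CCC=C(C)C)ccc1O` gives > 49000 nM

In a functional assay on Jurkat cells (Homo sapiens) for cytotoxicity, with a stated time of 72 h (on this read-out lower numbers stand for an effect already at smaller amounts and higher numbers for an effect only at larger amounts of compound), compound 3 gives > 49000 nM as a limit of the assay, not a number. The whole set sits at the same point: the limit of > 49000 nM in this assay, at which 3 of the 3 values shown sit. Compound 4 `COc1ccc(/C=C/[C@@](C)(/C=C/c2ccc(O)c(/C=C/C(=O)OCc3ccccc3)c2)CCC=C(C)C)cc1` carries 2-(benzyloxycarbonyl)ethenyl in place of 2-(ethoxycarbonyl)prop-1-en-1-yl on an aromatic carbon, ortho to a hydroxy group: 2-(benzyloxycarbonyl)ethenyl in place of 2-(ethoxycarbonyl)prop-1-en-1-yl on an aromatic carbon. Three earlier swaps at this place bear on the change: a step that the two limits leave unreadable from compound 1 to compound 2 and a step that the two limits leave unreadable from compound 1 to compound 3 and a step that the two limits leave unreadable from compound 2 to compound 3. None of them has a readable size, and they give no direction. The expected outcome is therefore a number no higher from compound 3 to compound 4 (the limit leaves the size open) with no direction favoured. Compound 4 is estimated at 49000 nM, within a range from 20000 nM to 80000 nM, and will most likely be reported as a limit again.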

Compound 4, half-maximal effective concentration: > 49000 nM
Compound 4: no number, only a limit; the forecaster's own chance of this, stated with the estimate: 75%; the middle value lies on the limit itself.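

For the compounds shown here, compound 4 ends at a limit, as do compound 1, compound 2 and compound 3, so no step to compound 4 can be read: the limit of > 49000 nM in this assay, at which 4 of the 4 values shown sit. These compounds leave open whether any of these groups changes the effect, and in which direction.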